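Replacing the Thiazole by a Methylpyrazole on the Enone Arm

A few compounds are considered here, and "the series" means these few. Any claim that something is new, unique, unknown or untested is made for them only; others in the source may bear on it.

Compound 1 `O=C(/C=C/c1nccs1)c1cc(O)c(O)c([N+](=O)[O-])c1` was tested in an assay on isolated protein for inhibition of Amine oxidase [flavin-containing] B (Homo sapiens), read by fluorescence (a lower number here means a stronger inhibitor, a higher number a weaker inhibitor), and gives 59200 nM. Compound 2 `N#Cc1ccc(/C=C/C(=O)c2cc(O)c(O)c([N+](=O)[O-])c2)cc1` gives 56600 nM in this assay, and compound 3 `CC(=O)N1N=C(c2cc(O)c(O)c([N+](=O)[O-])c2)CC1c1nccs1` gives 68200 nM. Compound 1 stands second highest of these three numbers, yet its gaps to compound 2 and to compound 3 both lie within the scatter, so the three cannot be told apart. Compound 4 `Cn1cc(/C=C/C(=O)c2cc(O)c(O)c([N+](=O)[O-])c2)cn1` differs from compound 1 by 1-methyl-1H-pyrazol-4-yl in place of 1,3-thiazol-2-yl on a double-bonded chain carbon bound to a double-bonded chain carbon. Within the data shown here, no pair of measured compounds shows what such a change does, so no step beyond the scatter is expected in either direction, and the estimated step of a 1.0-fold higher number from compound 1 to compound 4 (0.01 log units; within the scatter) reflects that. Compound 4 is therefore expected to give about 60000 nM in this assay, within a range from 25000 nM to 145000 nM.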

Compound 4, half-maximal inhibitory concentration: 66200 nM
Compound 4: the middle estimate sits 1.1-fold (0.04 log units) below what was measured; low and high end bracket the measured number.
By their numbers in this assay, from the lowest: compounds 2, 1, 4 and 3 (each within the scatter of the next).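

In this assay, 1-methyl-1H-pyrazol-4-yl in place of 1,3-thiazol-2-yl gives a 1.1-fold higher number from compound 1 to compound 4 (0.05 log units; within the scatter), the first step read at this place, on a double-bonded chain carbon bound to a double-bonded chain carbon. One five-membered aromatic ring with 2 hetero atoms thus replaces another here without a step beyond the scatter. Nothing at hand gives a cause for this result. The compounds shown leave open what an amine or a carboxylic acid at this place would do. They also leave open whether a longer chain in place of the methyl on the pyrazole would move the number beyond the scatter.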